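Bromo in place of trifluoromethyl: a small step expected

This account rests on a few compounds, and the source may have more. Where it says the series, first, only, none or still open, it means among the compounds named here.

Measured compounds and their values in a functional assay on B16-F10 cells (Mus musculus) for antiproliferative activity, read by MTT assay, with a stated time of 48 h; a higher number here means a weaker inhibitor, a lower number a stronger inhibitor:
compound 1 `CCOc1ccc(C(=O)/C=C/c2c(/C=C/c3ccc(OC)cc3)cc(OC)cc2OC)cc1` gives 6.4 ug/mL
compound 2 `COc1ccc(/C=C/c2cc(OC)cc(OC)c2/C=C/C(=O)c2ccc(N)cc2)cc1` gives 2.8 ug/mL
compound 3 `COc1ccc(/C=C/c2cc(OC)cc(OC)c2/C=C/C(=O)c2ccc(C(F)(F)F)cc2)cc1` gives 4.3 ug/mL

The three compounds share one core and differ only in a single group sitting on an aromatic carbon. Compound 3, the trifluoromethyl-bearing member, stands second highest of the three numbers. Its nearest neighbour is compound 1, with the step of a 1.5-fold lower number from compound 1 to compound 3 (0.17 log units; within the scatter), and on the other side lies compound 2, with the step of a 1.5-fold higher number from compound 2 to compound 3 (0.19 log units; within the scatter). For the measured compounds named here, the only step in this set that reaches beyond the scatter is a 2.3-fold lower number from compound 1 to compound 2 (0.36 log units; beyond the scatter), and even that one is modest.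

Compound 4 `COc1ccc(/C=C/c2cc(OC)cc(OC)c2/C=C/C(=O)c2ccc(Br)cc2)cc1` differs from compound 3 in one place: bromo in place of trifluoromethyl on an aromatic carbon. Going by the values given here, no measured step involves bromo, so the expectation can rest only on the pattern that changes at this aromatic carbon have so far moved this assay little. Among the compounds with values here, both steps that lead to compound 3 stayed within the scatter, and the one step beyond it was small. The step to compound 4 is therefore expected to be a 1.1-fold lower number from compound 3 to compound 4 (0.03 log units; within the scatter), with no clear direction. Compound 4 is estimated at 4 ug/mL, within a range from 2 ug/mL to 8 ug/mL.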

Compound 4, half-maximal inhibitory concentration: 6.5 ug/mL
Beside the measured number, compound 4's estimate is 1.6-fold (0.21 log units) below it; low and high end bracket the measured number.
By their numbers in this assay, from the lowest: compounds 2, 3, 1 and 4 (each within the scatter of the next, the first and the last beyond it).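

In this assay, bromo in place of trifluoromethyl gives a 1.5-fold higher number from compound 3 to compound 4 (0.18 log units; within the scatter) and bromo in place of ethoxy gives a 1.0-fold higher number from compound 1 to compound 4 (0.01 log units; within the scatter) so bromo joins these two groups as one more substituent on this aromatic carbon that cannot be told apart from them in this read-out. The amino compound now has a second step beyond the scatter, a 2.3-fold higher number from compound 2 to compound 4 (0.37 log units; beyond the scatter) alongside a 2.3-fold lower number from compound 1 to compound 2 (0.36 log units; beyond the scatter) so amino separates modestly from both bromo and ethoxy, although compound 3 goes against any clean split, since trifluoromethyl stays within the scatter of all three other groups. Nothing measured alongside these numbers offers an explanation for the separation of amino from the other groups.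

On these data alone, whether that separation belongs to amino alone remains open, and a hydroxy group, a dimethylamino group or a carboxylic acid on the same carbon would test it. Also open, as far as these compounds go, is whether bromo would give a similar reading on a different carbon of this six-membered ring.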